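The source may hold more compounds than are shown below. What is called first, only, known or untested is meant among the compounds shown, and "the series" means these compounds.

Compound 1 `Cc1c(F)cccc1CCCCOc1ccc(C#Cc2cccc3c(CCCC(=O)O)c(C)n(CCCC(=O)O)c23)cc1`: 1.1 nM
Compound 2 `O=C(O)CCCc1cn(CC(=O)O)c2c(/C=C/c3ccc(OCCCCc4c(F)ccc(F)c4F)cc3)cccc12`: 1 nM

In a functional assay on CHO-K1 cells for antagonist activity at cysteinyl leukotriene receptor 1 (Homo sapiens), read by fluorescence and calcium flux, with stated times of 30 min and 1 h (on this read-out higher numbers stand for weaker inhibition and lower numbers for stronger inhibition), compound 2 gives 1 nM, the lowest of the two numbers shown, while compound 1 gives 1.1 nM; the gap between them lies within the scatter of repeated measurements, so the two cannot be told apart. Compound 3 `Cc1c(F)cccc1CCCCOc1ccc(/C=C/c2cccc3c(CCCC(=O)O)cn(CC(=O)O)c23)cc1` differs from compound 2 in one place: 3-fluoro-2-methylphenyl in place of 2,3,6-trifluorophenyl on a saturated chain carbon, four bonds along the chain from an oxygen on an aromatic ring. Among the measured compounds shown here, no measured pair isolates this single change. Because compound 2 gives 1 nM and compound 1 gives 1.1 nM, two values that sit so close, the step expected from this change is small, a 1.2-fold higher number from compound 2 to compound 3 (0.08 log units; within the scatter), with no direction favoured beyond the scatter. Compound 3 is estimated at 1.2 nM, within a range from 0.5 nM to 3 nM.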

Compound 3, half-maximal inhibitory concentration: 2.9 nM
Compound 3: middle estimate off by 2.4-fold (0.38 log units), on the low side; measured number inside the range.
By their numbers in this assay, from the lowest: compounds 2 and 1 (each within the scatter of the next); then compound 3.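

In this assay, 3-fluoro-2-methylphenyl in place of 2,3,6-trifluorophenyl gives a 2.9-fold higher number from compound 2 to compound 3 (0.46 log units; beyond the scatter). The number therefore responds to the group at the end of this chain, though only modestly, which compounds 1 and 2 could not show, as they differ in more than one place. Nothing measured here explains the shift. Going by these compounds, the swap removes two fluorines and adds a methyl at once, and which of these carries the step stays open. Also open, on these data alone, is how plain phenyl or a pyridine ring would read at this position.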